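Swapping an ethoxy for an ethyl on an anilino ring

The compounds below may be only part of what the source reports. "The series", "measured", "known", "first", "only" and "open" are said of these compounds alone.

Of the compounds shown here, three sharing a sugar-fused quinone core have been tested in a functional assay on MCF7 cells (Homo sapiens) for inhibition, read by sulforhodamine B assay; a lower number here means a stronger inhibitor, a higher number a weaker inhibitor. Compound 1, `CCOc1ccc(NC2=CC(=O)c3c(nc4n3[C@H]3OC[C@@H](O)[C@H]3OC4)C2=O)cc1`, carries an ethoxy on its anilino ring. In this assay compound 1 reaches only the limit of > 4000 nM. Compound 2, `O=C1C=C(Nc2ccccc2)C(=O)c2c1nc1n2[C@H]2OC[C@@H](O)[C@H]2OC1`, has a plain anilino ring on a core arranged slightly differently. In this assay compound 2 likewise stops at the limit of > 4000 nM. Going by the values given here, compound 3, `CCOc1ccc(NC2=CC(=O)c3nc4n(c3C2=O)[C@H]2OC[C@@H](O)[C@H]2OC4)cc1`, adds an ethoxy to that second core and in this assay gives 1430 nM, so the single measured step reads an at least 2.7-fold lower number from compound 2 to compound 3 (0.44 log units; beyond the scatter).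

Compound 4, `CCc1ccc(NC2=CC(=O)c3c(nc4n3[C@H]3OC[C@@H](O)[C@H]3OC4)C2=O)cc1`, differs from compound 1 by ethyl in place of ethoxy on an aromatic carbon. Among the compounds with values here, no measured step covers this swap; the only step known concerns adding an ethoxy, not replacing it. The estimate therefore leans on where compound 1 stands, because of the limit of > 4000 nM in this assay, at which 2 of the 3 values shown sit. Compound 4 is expected to give 5000 nM, between 1500 nM and 16000 nM. The expected step is thus a step that the limit leaves unreadable from compound 1 to compound 4, and a limit rather than a number is the likelier outcome.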

Compound 4, half-maximal inhibitory concentration: 8990 nM
Compound 4: middle estimate off by 1.8-fold (0.25 log units), on the low side; low and high end bracket the measured number.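

The step from compound 1 to compound 4 cannot be read, because compound 1 has a limit rather than a number: the limit of > 4000 nM in this assay, at which 2 of the 4 values shown sit. The compounds shown leave open whether ethoxy or ethyl on the anilino ring gives the stronger inhibitor on this shared core.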